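A few compounds are considered here, and "the series" means these few. Any claim that something is new, unique, unknown or untested is made for them only; others in the source may bear on it.

Values measured in a functional assay on B16 cells (Mus musculus) for cytotoxicity, read by CCK-8 assay, with a stated time of 24 h; a lower number here means a stronger inhibitor, a higher number a weaker inhibitor

Compound 1 (`COc1ccccc1Oc1c(N)nc(-c2ccccc2)nc1OCCO`) gives 31100 nM
Compound 2 (`COc1ccc(-c2nc(N)c(Oc3ccccc3OC)c(OCCO)n2)cc1`) gives 18100 nM
Compound 3 (`COc1ccccc1Oc1c(N)nc(-c2ccc(F)cc2)nc1OCCO`) gives 30100 nM

Compound 3 at 30100 nM does not separate from either of the other two compounds. The data show a 1.0-fold lower number from compound 1 to compound 3 (0.01 log units; within the scatter) and a 1.7-fold higher number from compound 2 to compound 3 (0.22 log units; within the scatter) in this series. Compound 4 (`COc1ccccc1Oc1c(N)nc(-c2ccc(I)cc2)nc1OCCO`) differs from compound 3 by iodo in place of fluoro on an aromatic carbon, para to a large group (iodo in place of fluoro on an aromatic carbon). Within the data shown here, no compound with iodo has been measured yet, so the evidence is indirect. The other exchange at this same place is a 1.7-fold lower number from compound 1 to compound 2 (0.24 log units; within the scatter) and it too stays small, like the two steps above. No step beyond the scatter is therefore expected in this assay for this exchange, although three compounds are a thin basis. The estimated step is a 1.2-fold lower number from compound 3 to compound 4 (0.06 log units; within the scatter) as the expected outcome. Compound 4 is expected at 26000 nM in a range from 13000 nM to 45000 nM by this estimate.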

Compound 4, half-maximal inhibitory concentration: 19600 nM
Beside the measured number, compound 4's estimate is 1.3-fold (0.12 log units) above it; the range from low to high includes it.
By their numbers in this assay, from the lowest: compounds 2, 4, 3 and 1 (each within the scatter of the next).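

In this assay, the change from 4-fluorophenyl to 4-iodophenyl gives a 1.5-fold lower number from compound 3 to compound 4 (0.19 log units; within the scatter) and does not move the number beyond the scatter. Iodo also fails to separate from the other groups at this place on the aromatic carbon, with a 1.1-fold higher number from compound 2 to compound 4 (0.03 log units; within the scatter) for methoxy and a 1.6-fold lower number from compound 1 to compound 4 (0.20 log units; within the scatter) for hydrogen, so hydrogen, fluoro, methoxy and iodo cannot be told apart here, and the flat picture from the earlier compounds now extends to a fourth group. Nothing available offers an explanation for these numbers.

As far as these compounds go, whether any group at this place can produce a step beyond the scatter remains open, and an amine or a carboxylic acid on the same aromatic carbon would be a further test. The compounds shown also leave open how the number responds to a change elsewhere on the shared core, such as a longer chain carrying the hydroxyl.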